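The source may report more compounds than this note shows. Statements on the series, on what has been measured and on what is new or still open speak of the compounds shown alone.

Measured compounds:
Compound 1, `O=C(Nc1ccnnc1)c1cc(N2CCCCC2)ccc1OCc1ccccc1`, in an assay on Sf9 cells for inhibition of Leucine-rich repeat serine/threonine-protein kinase 2 (Homo sapiens), read by TR-FRET, with stated times of 30 min and 2 h (on this read-out higher numbers stand for weaker inhibition and lower numbers for stronger inhibition), gives 25.1 nM.
Compound 2, `O=C(Nc1cccc(Cl)c1)c1cc(C(F)(F)F)ccc1OCc1ccccc1`, in this assay gives 25.1 nM.
Compound 3, `CN1CCC(c2ccc(OCc3ccccc3)c(C(=O)Nc3ccnnc3)c2)CC1`, in this assay gives 20 nM.

Compound 3 shows the lowest of the three numbers, but its distance to compound 1 and to compound 2 lies within the scatter, so the three compounds cannot be separated on these data. For the measured compounds named here, the only step joining two measured compounds, a 1.3-fold lower number from compound 1 to compound 3 (0.10 log units; within the scatter), exchanges the piperidin-1-yl of compound 1 for the 1-methylpiperidin-4-yl of compound 3 and leaves the number essentially unchanged. Compound 4, `O=C(Nc1ccnnc1)c1cc(N2CCCC2)ccc1OCc1ccccc1`, is reached from compound 3 by the change (pyrrolidin-1-yl in place of 1-methylpiperidin-4-yl on an aromatic carbon). This resembles the measured step run in reverse, a saturated ring again joined through its nitrogen to the aromatic carbon, here as a five-membered ring. Since the measured step stayed within the scatter, no shift beyond the scatter is expected in this assay for this change either. Compound 4 is therefore expected to give 25 nM, with a range from 10 nM to 63 nM. The expected step is a 1.3-fold higher number from compound 3 to compound 4 (0.10 log units; within the scatter).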

Compound 4, half-maximal inhibitory concentration: 20 nM
Compound 4: middle estimate off by 1.3-fold (0.10 log units), on the high side; the measured number falls inside the stated range.
By their numbers in this assay, from the lowest: compounds 3, 4, 1 and 2 (each within the scatter of the next).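

On the aromatic carbon para to the benzyloxy group, pyrrolidin-1-yl in place of 1-methylpiperidin-4-yl gives no change at the digits printed from compound 3 to compound 4 (within the scatter) in this assay and thus adds a five-membered ring to the six-membered rings already seen at this position. Pyrrolidin-1-yl in place of piperidin-1-yl gives a 1.3-fold lower number from compound 1 to compound 4 (0.10 log units; within the scatter) and so shows that, among these three saturated rings, neither ring size nor the way the ring is attached separates the compounds on these data. Nothing available accounts for this lack of separation.

Still open, from the compounds shown here alone, is whether a morpholine ring, a primary amine or a carboxylic acid on this carbon would also stay within the scatter. The compounds shown also leave open whether a ring larger than piperidine or a longer chain would do so.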